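Swapping the Halogen on the Anilino Ring of Compound 1

The source may report more compounds than this note shows. Statements on the series, on what has been measured and on what is new or still open speak of the compounds shown alone.

In a functional assay on BT-474 cells (Homo sapiens) for cytotoxicity, read by MTT assay, with a stated time of 48 h (a higher number here means a weaker inhibitor, a lower number a stronger inhibitor), compound 1 `COc1ccc(-c2nc(C(=O)/C=C\Nc3ccc(Cl)cc3)c3ccccn23)cc1` gives 37300 nM, the highest number of the three measured, so it is the weakest of them. Compound 2 `O=C(/C=C\Nc1ccc(Cl)cc1)c1nc(-c2ccc(C(F)(F)F)cc2)n2ccccc12` gives 3820 nM, and compound 3 `O=C(/C=C\Nc1ccc(Cl)cc1)c1nc(-c2ccc(F)cc2)n2ccccc12` gives 7030 nM. Both measured steps, a 9.8-fold lower number from compound 1 to compound 2 (0.99 log units; beyond the scatter) and a 5.3-fold lower number from compound 1 to compound 3 (0.72 log units; beyond the scatter), alter the group on the other aryl ring, not the anilino ring. Compound 4 `COc1ccc(-c2nc(C(=O)/C=C\Nc3ccc(F)cc3)c3ccccn23)cc1` differs from compound 1 by fluoro in place of chloro on an aromatic carbon. For the measured compounds named here, no measured step touches that position, so there is nothing to anchor a direction, and the expected step of a 1.1-fold higher number from compound 1 to compound 4 (0.03 log units; within the scatter) is one within the scatter. Compound 4 is therefore estimated at 40000 nM in this assay, with a range from 15000 nM to 100000 nM.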

Compound 4, half-maximal inhibitory concentration: > 30000 nM
Compound 4 gave a limit, no number (the forecaster's own chance of this, stated with the estimate: 15%); the middle value lies beyond the limit too.
By their numbers in this assay, from the lowest: compounds 2 and 3 (each within the scatter of the next); then compound 1.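

For the compounds shown here, compound 4 gives > 30000 nM, which is a limit of the assay and not a number, so no step from compound 1 can be read. The compounds shown leave open whether fluoro in place of chloro changes the number in this assay, and in which direction.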